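Trimethoxyphenyl series: acetyl cyclised analogue with trifluoromethylphenyl

A few compounds are considered here, and "the series" means these few. Any claim that something is new, unique, unknown or untested is made for them only; others in the source may bear on it.

Measured so far:
compound 1 `COc1cc(C(=O)N/N=C/c2cccc(C(F)(F)F)c2)cc(OC)c1OC`: 33.8%
compound 2 `COc1ccc(OC)c(C2OC(c3cc(OC)c(OC)c(OC)c3)=NN2C(C)=O)c1`: 18.2%
compound 3 `COc1cc(C(=O)N/N=C/c2ccc(C(F)(F)F)cc2)cc(OC)c1OC`: 56.3%

In a functional assay on BGC-823 cells (Homo sapiens) for antiproliferative activity, read by MTT assay, tested at 5 uM (a lower number here means a weaker effect, a higher number a stronger effect of the compound at the concentration tested), compound 2 gives the lowest of the three numbers; compound 1 stands higher by a margin beyond the scatter, and compound 3 higher still, also beyond the scatter. Compound 4 `COc1cc(C2=NN(C(C)=O)C(c3cccc(C(F)(F)F)c3)O2)cc(OC)c1OC` differs from compound 2 in one place: 3-(trifluoromethyl)phenyl in place of 2,5-dimethoxyphenyl on a saturated ring carbon. Among the compounds with values here, no measured pair shows this exact change, so its size is open. Compound 1, which also bears a 3-(trifluoromethyl)phenyl group, gives 33.8%, and on that basis a moderate upward step from compound 2 to compound 4 is expected, about a number 11.8 percentage points higher from compound 2 to compound 4 (beyond the scatter). Compound 4 is estimated at 30%, in a range of 12% to 50%.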

Compound 4, a percentage reported as inhibition, at one concentration (the size of the read-out at that concentration, not a potency): 41.1%
Beside the measured number, compound 4's estimate is 11.1 percentage points below it; the measured number falls inside the stated range.
By their numbers in this assay, from the lowest: compound 2; then compounds 1 and 4 (each within the scatter of the next); then compound 3.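

In this assay, within the data shown here, 3-(trifluoromethyl)phenyl in place of 2,5-dimethoxyphenyl on the saturated ring carbon gives a number 22.9 percentage points higher from compound 2 to compound 4 (beyond the scatter), the first direct reading of a change at this position. The saturated ring carbon is therefore sensitive to which aryl group it carries, even at an unchanged heavy-atom count. Nothing available explains the step.

The compounds shown leave open whether the step follows from losing the methoxy groups or from gaining trifluoromethyl. An unsubstituted phenyl group or a carboxylic acid-bearing phenyl group at this carbon would help separate these readings.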